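A few compounds are considered here, and "the series" means these few. Any claim that something is new, unique, unknown or untested is made for them only; others in the source may bear on it.

In a functional assay on MCF7 cells (Homo sapiens) for inhibition, read by MTT assay, with a stated time of 48 h (a lower number here means a stronger inhibitor, a higher number a weaker inhibitor), compound 2 `COc1cc(N(Cc2ccccc2)S(=O)(=O)c2ccc(C)cc2)cc(OC)c1OC` gives 10200 nM, and compound 3 `COc1cc(N(Cc2nc3ccccc3[nH]2)S(=O)(=O)c2ccc(C)cc2)cc(OC)c1OC` gives 5400 nM. Compound 1 `COc1ccc(CN(c2cc(OC)c(OC)c(OC)c2)S(=O)(=O)c2ccccc2)cc1` reaches only the limit of > 50000 nM. The step of a 1.9-fold lower number from compound 2 to compound 3 (0.28 log units; within the scatter) lies within the scatter, so compound 3 holds the lowest of the two numbers while sitting within the scatter of compound 2. Compound 4 `COc1cc(N(Cc2nc3ccccc3[nH]2)S(=O)(=O)c2ccccc2)cc(OC)c1OC` differs from compound 3 by hydrogen in place of methyl on an aromatic carbon. Going by the values given here, no measured step tests this change: the one known step concerns a different group, and compound 1 differs from compound 2 at a second place as well, so the pair tells nothing about the methyl alone. The expected step of a 1.1-fold higher number from compound 3 to compound 4 (0.05 log units; within the scatter) is therefore small, within the scatter. Compound 4 is estimated at 6000 nM, between 2500 nM and 15000 nM.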

Compound 4, half-maximal inhibitory concentration: 27300 nM
For compound 4 the middle estimate is 4.6-fold (0.66 log units) below the measured one, outside the stated range (above it).
By their numbers in this assay, from the lowest: compounds 3 and 2 (each within the scatter of the next); then compound 4. At a limit, above all of these: compound 1.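

With the 1H-benzimidazol-2-yl group held fixed, changing 4-methylphenyl to phenyl gives a modest measured step beyond the scatter: in this assay there is a 5.1-fold higher number from compound 3 to compound 4 (0.70 log units; beyond the scatter) on losing a single methyl group. That one carbon on the aromatic ring therefore matters in this pair. Compound 1 stands at a limit, not a number: the limit of > 50000 nM in this assay, at which 1 of the 4 values shown sits. The step that rests on this limit gives only a floor: there is an at least 1.8-fold lower number from compound 1 to compound 4 (0.26 log units; that floor lies within the scatter).

Going by these compounds, whether the methyl counts the same with phenyl on the saturated chain carbon stays open. So does what an ethyl group, a chlorine atom or an amine would give at that aromatic carbon.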